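This account rests on a few compounds, and the source may have more. Where it says the series, first, only, none or still open, it means among the compounds named here.

Going by the values given here, in an ADME assay on microsomes from liver (Homo sapiens) for metabolic stability, read by LC-MS, with a stated time of 60 min (on this read-out lower numbers stand for a less stable compound and higher numbers for a more stable compound), only two compounds with the shared core have numbers so far. Compound 1 (`CCc1ccc(N(C2CCC2)S(=O)(=O)c2ccc3c(c2)C(O)CC(C2CCOCC2)O3)cc1`) gives 45.1% of the compound remaining. Compound 2 (`CC(C)CN(c1ccc(C#N)cc1)S(=O)(=O)c1ccc2c(c1)C(O)CC(C1CCOCC1)O2`) gives 0.3%, the lower of the two numbers, and the gap between them lies well beyond the usual scatter of the measurement.

Compound 3 (`CC(C)CN(c1cc2ccccc2s1)S(=O)(=O)c1ccc2c(c1)C(O)CC(C1CCOCC1)O2`) follows from compound 2 with one exchange, 1-benzothiophen-2-yl in place of 4-cyanophenyl on a sulfonamide nitrogen. Among the compounds with values here, no measured pair of compounds differs in only one place, so the data offer no direct precedent for the size of this step. With compound 2 at 0.3%, there is almost no room for a fall, so any real change is expected to be upward. Nothing in the two measured compounds points to a large recovery, however. The expected change is a number 7.7 percentage points higher from compound 2 to compound 3 (within the scatter), a modest rise that would not clearly leave the scatter. For compound 3 the estimated value in this assay is 8%, with an expected range from 0.5% to 30%.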

Compound 3, percent of the compound remaining: 28.5%
Compound 3: middle estimate off by 20.5 percentage points, on the low side; the range from low to high includes it.
By their numbers in this assay, from the lowest: compound 2; then compound 3; then compound 1.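

Exchanging 4-cyanophenyl for 1-benzothiophen-2-yl on a sulfonamide nitrogen gives a number 28.2 percentage points higher from compound 2 to compound 3 (beyond the scatter) in this assay, and this is the first change in one place that can be read among these compounds. It shows that the group at this position, on a nitrogen whose other neighbours are a saturated chain carbon and a sulfonyl sulfur, can by itself move this read-out beyond the scatter, even with the rest of the molecule held fixed. The exchange removes a nitrile and brings in a five-membered aromatic ring with a sulfur atom in a single step, and nothing available explains why the read-out moves.

Going by these compounds alone, the single step cannot separate the loss of the nitrile from the gain of the new ring system, so it remains open whether a plain phenyl or a 1-benzofuran-2-yl at this position would give a number close to that of compound 3. Also open, on these data alone, is whether the step would hold with a cyclobutyl on the same sulfonamide nitrogen.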